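This account rests on a few compounds, and the source may have more. Where it says the series, first, only, none or still open, it means among the compounds named here.

Of the compounds shown here, two with a shared core have been measured in an ADME assay for permeability, using PAMPA, with a stated time of 30 min, at pH 7.4; on this read-out higher numbers stand for higher permeability and lower numbers for lower permeability. Compound 1 `COc1cccc(CNCCCNc2ccnc3cc(-c4ccc(F)cc4)ccc23)c1O` carries a 4-fluorophenyl group on the aromatic carbon of its core, and in this assay compound 1 gives 237 10^-6 cm/s. Compound 2 `COc1cccc(CNCCCNc2ccnc3cc(CCC(C)C)ccc23)c1O` carries an isopentyl group at the same place, and in this assay compound 2 gives 23 10^-6 cm/s. Among the compounds with values here, that single exchange brought a 10-fold lower number from compound 1 to compound 2 (1.01 log units; beyond the scatter), so compound 2 stands as the lower of the two numbers, with compound 1 as its only and higher neighbour.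

Compound 3 `COc1ccc(Oc2ccc3c(NCCCNCc4cccc(OC)c4O)ccnc3c2)cc1` is not yet measured. It differs from compound 2 in one place: 4-methoxyphenoxy in place of isopentyl on an aromatic carbon. Within the data shown here, the only measured step that bears on this change is the one from compound 1 to compound 2, in which an aromatic group gave way to the isopentyl chain and the number fell by a large amount. Compound 3 reverses that direction of change, bringing an aromatic ring back to the same position, though with an ether oxygen and a methoxy group in place of the fluorine. A large rise is therefore expected for compound 3, namely a 5.2-fold higher number from compound 2 to compound 3 (0.72 log units; beyond the scatter). Compound 3 is thus estimated at 120 10^-6 cm/s, with a range from 40 10^-6 cm/s to 300 10^-6 cm/s.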

Compound 3, apparent permeability: 317 10^-6 cm/s
Beside the measured number, compound 3's estimate is 2.6-fold (0.42 log units) below it, and the stated range ends below it.
By their numbers in this assay, from the lowest: compound 2; then compounds 1 and 3 (each within the scatter of the next).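

In this assay, 4-methoxyphenoxy in place of isopentyl on this aromatic carbon gave a 14-fold higher number from compound 2 to compound 3 (1.14 log units; beyond the scatter) and so a large step, which shows that the gap to the isopentyl compound is not confined to the 4-fluorophenyl group: a second group with a six-membered aromatic ring of carbon only also stands well clear of it. The direct exchange of 4-fluorophenyl for 4-methoxyphenoxy gave a 1.3-fold higher number from compound 1 to compound 3 (0.13 log units; within the scatter) and thus no difference that can be told from the scatter, so at this position the ether oxygen and the methoxy group, taken together in place of the fluorine and the direct ring attachment, leave the read-out where it was. What lies behind the gap between these two groups and the isopentyl chain remains unexplained, as no supporting data accompany these numbers.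

With only three groups at this one position, the compounds shown cannot say whether the aromatic ring itself is what separates compound 1 and compound 3 from compound 2. A cyclohexyl ring, a shorter alkyl chain or a morpholine at the same carbon would test that, and an amine or a carboxylic acid there would show how far the read-out holds up with a charged group.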